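Dimethoxy Substitution on the Benzyl Group and Vero Cytotoxicity

A few compounds are considered here, and "the series" means these few. Any claim that something is new, unique, unknown or untested is made for them only; others in the source may bear on it.

Measured compounds in an ADME assay on Vero cells (Chlorocebus sabaeus) for cytotoxicity, read by MTT assay, with a stated time of 48 h; a higher number here means a weaker inhibitor, a lower number a stronger inhibitor:
Compound 1, `O=c1nc(NCc2ccc(F)cc2)oc2c([N+](=O)[O-])cc(C(F)(F)F)cc12`, gives only a limit, > 64 ug/mL.
Compound 2, `O=c1nc(NCC2CCCCC2)oc2c([N+](=O)[O-])cc(C(F)(F)F)cc12`, gives 29.7 ug/mL.
Compound 3, `O=c1nc(NCc2ccccc2)oc2c([N+](=O)[O-])cc(C(F)(F)F)cc12`, gives 25.4 ug/mL.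

Compound 3 holds the lowest of the two numbers given, and its nearest number is that of compound 2. That gap is a 1.2-fold lower number from compound 2 to compound 3 (0.07 log units; within the scatter). Compound 4, `COc1ccc(CNc2nc(=O)c3cc(C(F)(F)F)cc([N+](=O)[O-])c3o2)cc1OC`, differs from compound 3 by 3,4-dimethoxyphenyl in place of phenyl on a saturated chain carbon bound to a nitrogen on an aromatic ring. Among the measured compounds shown here, two measured steps touch this place. One is the swap of ring type, a 1.2-fold lower number from compound 2 to compound 3 (0.07 log units; within the scatter). The other is a change of substituent on the aromatic ring, an at least 2.5-fold lower number from compound 1 to compound 3 (0.40 log units; beyond the scatter), which moved the number beyond the scatter. Putting 3,4-dimethoxyphenyl in place of phenyl is expected to give a step of a 1.2-fold higher number from compound 3 to compound 4 (0.07 log units; within the scatter) in this assay, probably within the scatter, with some chance of a higher number. Compound 4 is therefore estimated at 30 ug/mL, ranging from 14 ug/mL to 64 ug/mL.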

Compound 4, half-maximal inhibitory concentration: 29.2 ug/mL
Beside the measured number, compound 4's estimate is 1.0-fold (0.01 log units) above it; the range from low to high includes it.
By their numbers in this assay, from the lowest: compounds 3, 4 and 2 (each within the scatter of the next). At a limit, above all of these: compound 1.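

In this assay, 3,4-dimethoxyphenyl in place of phenyl gives a 1.1-fold higher number from compound 3 to compound 4 (0.06 log units; within the scatter), and in place of cyclohexyl it gives a 1.0-fold lower number from compound 2 to compound 4 (0.01 log units; within the scatter), so at this position neither change moves the number beyond the scatter. Against 4-fluorophenyl the same group gives an at least 2.1-fold lower number from compound 1 to compound 4 (0.34 log units; beyond the scatter). Compound 1 gives only a limit of the assay: the limit of > 64 ug/mL in this assay, at which 1 of the 4 values shown sits.

The compounds shown leave open whether an amine or a carboxylic acid on the aromatic ring, or a longer chain on the nitrogen, would stay with compound 2, compound 3 and compound 4 or go with compound 1. They also leave open whether a single methoxy group behaves as the pair does.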